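Carbonyl substituent changes and cytotoxicity in the series

A few compounds are considered here, and "the series" means these few. Any claim that something is new, unique, unknown or untested is made for them only; others in the source may bear on it.

Among the compounds with values here, compound 1 `CC(=O)Nc1ncc(SCc2ncc(C(C)(C)C)o2)s1` carries a methyl on its carbonyl carbon; in a functional assay on A2780 cells (Homo sapiens) for cytotoxicity (on this read-out higher numbers stand for weaker inhibition and lower numbers for stronger inhibition), compound 1 gives 50 nM, the lowest of the three numbers measured so far. Compound 2 `CC(C)(C)c1cnc(CSc2cnc(NC(=O)OCc3ccccc3)s2)o1` has benzyloxy at that position and in this assay compound 2 gives 1040 nM; compound 3 `CC(C)(C)c1cnc(CSc2cnc(NC(=O)Nc3c(F)cccc3F)s2)o1` has (2,6-difluorophenyl)amino there and in this assay compound 3 gives 240 nM. The steps are a 21-fold higher number from compound 1 to compound 2 (1.32 log units; beyond the scatter), a 4.8-fold higher number from compound 1 to compound 3 (0.68 log units; beyond the scatter) and a 4.3-fold lower number from compound 2 to compound 3 (0.64 log units; beyond the scatter), so every replacement of the methyl measured so far has raised the number, the benzyloxy much more than the (2,6-difluorophenyl)amino.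

Compound 4 `CC(C)(C)c1cnc(CSc2cnc(NC(=O)Nc3c(Cl)cccc3Cl)s2)o1` has not yet been measured. It differs from compound 1 by (2,6-dichlorophenyl)amino in place of methyl on a carbonyl carbon. The step from compound 1 to compound 3 is the one that bears on this, since it puts a halogenated phenylamino on the same carbonyl carbon, and it was modest and upward. Within the data shown here, a step of similar size and direction is therefore expected, a 6.0-fold higher number from compound 1 to compound 4 (0.78 log units; beyond the scatter), with no measured pair indicating whether chlorine in place of fluorine shifts it further. In this assay compound 4 is estimated at 300 nM, with a range from 80 nM to 1100 nM that allows for it landing near compound 3 or somewhat beyond.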

Compound 4, half-maximal inhibitory concentration: 1500 nM
The estimate for compound 4 lay 5.0-fold (0.70 log units) below the measured number; measured number above the stated range.
By their numbers in this assay, from the lowest: compound 1; then compound 3; then compounds 2 and 4 (each within the scatter of the next).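

Within the data shown here, at this position the halogen on the phenylamino counts for more than the earlier compounds could show: with only 2,6-dichlorophenyl in place of 2,6-difluorophenyl on the amide-type nitrogen, the change is (a 6.3-fold higher number from compound 3 to compound 4 (0.80 log units; beyond the scatter)), so a halogenated phenylamino does not behave as one kind of replacement in this assay. The replacement of methyl on the carbonyl carbon now also gives a large step with an aryl amino group (a 30-fold higher number from compound 1 to compound 4 (1.48 log units; beyond the scatter)), and the step from benzyloxy is within the scatter (a 1.4-fold higher number from compound 2 to compound 4 (0.16 log units; within the scatter)), so a large rise is no longer confined to benzyloxy. Nothing available accounts for the gap between the two halogenated compounds.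

Still open, as far as these compounds go, is whether methyl is the best of the small groups on the carbonyl carbon, as ethyl, cyclopropyl or a plain amino group would show, and whether the number falls back with an unsubstituted phenylamino. Also open, from the compounds shown here alone, is whether one chlorine alone, or 2,6-dimethylphenyl on the amide-type nitrogen, gives a number nearer compound 3 or nearer compound 4.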